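The source may report more compounds than this note shows. Statements on the series, on what has been measured and on what is new or still open speak of the compounds shown alone.

Measured so far:
compound 1 `CCCNC(=O)CC1CCc2cc(OC)c(OC)cc21` with 22.2%
compound 2 `COc1cc2c(cc1OC)C(CC(=O)N1CCCC1)CC2` with 22.2%

In a functional assay on the whole organism (strain Wistar) for inhibition, with Rattus norvegicus as the target, read by paw edema, with stated times of 60 min and 6 h, at a dose of 100 mg/kg by the oral route (on this read-out lower numbers stand for less inhibition and higher numbers for more inhibition at the one dose given (going by the name of the read-out)), compound 1 gives 22.2%, level with compound 2 at the digits shown; the step of no change at the digits printed from compound 1 to compound 2 (within the scatter) lies within the scatter. Compound 3 `COc1cc2c(cc1OC)C(CC(=O)NCCO)CC2` differs from compound 1 by hydroxy in place of methyl on a saturated chain carbon, two bonds along the chain from an amide-type nitrogen. Among the compounds with values here, no measured step alters this part of the chain in the same way; the one step that reshapes the group on the carbonyl carbon, from compound 1 to compound 2, produced no change beyond the scatter. Compound 3 is therefore expected to stay close to compound 1, at an estimated 22% within 10% to 35%, an expected step of a number 0.2 percentage points lower from compound 1 to compound 3 (within the scatter).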

Compound 3, a percentage reported as inhibition, in the whole organism at one dose (the size of the read-out at that dose, not a potency): 13%
Compound 3: the middle estimate sits 9 percentage points above what was measured, within the range that was stated.
By their numbers in this assay, from the lowest: compounds 3, 1 and 2 (each within the scatter of the next).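

Hydroxy in place of methyl on a saturated chain carbon, two bonds along the chain from an amide-type nitrogen, is the first change shown at this part of the chain, and in this assay it reads as a number 9.2 percentage points lower from compound 1 to compound 3 (within the scatter). (2-Hydroxyethyl)amino in place of pyrrolidin-1-yl on a carbonyl carbon reads as a number 9.2 percentage points lower from compound 2 to compound 3 (within the scatter), so neither step separates the compounds beyond the scatter. Nothing available explains these readings.

The compounds shown leave open how an amine, a carboxylic acid or a longer chain in place of propyl would read in this assay. They also leave open whether any group on the carbonyl carbon can move the number beyond the scatter.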